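Pyridyl tetrazole series: rat liver stability working notes

The source may hold more compounds than are shown below. What is called first, only, known or untested is meant among the compounds shown, and "the series" means these compounds.

Three compounds of the series have a reading in an ADME assay on S9 fraction from liver (Rattus norvegicus) for metabolic stability, read by LC-MS, using NADPH, with a stated time of 30 min; on this read-out lower numbers stand for a less stable compound and higher numbers for a more stable compound. Compound 1 `CCCCCCCCc1ccc(OCC(=O)Cn2nnc(-c3cccnc3)n2)cc1` gives 12%. Compound 2 `CCCCCCCCc1ccc(OCC(=O)Cn2nnc(-c3ccccn3)n2)cc1` gives 30% in this assay. Compound 3 `CCCCCCCCc1ccc(OCC(=O)Cn2nnnc2-c2cccnc2)cc1`, built on a different core, gives 20% in this assay.

Among the measured compounds shown here, the one change measured so far is pyridin-2-yl in place of pyridin-3-yl on an aromatic carbon, and it moved the read-out a number 18 percentage points higher from compound 1 to compound 2 (beyond the scatter). The values of compound 3 and compound 1 lie within the scatter of each other, as do those of compound 3 and compound 2. How the core of compound 3 differs from the core of compound 1 is not broken down here.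

Compound 4 `CCCCCCCCc1ccc(OCC(=O)Cn2nnnc2-c2ccccn2)cc1` is not yet measured. It arises from compound 3 by pyridin-2-yl in place of pyridin-3-yl on an aromatic carbon. This is the same kind of change as from compound 1 to compound 2, but the surroundings differ: in compound 1 the changed carbon is two ring bonds from the ring atom that bears a large group, whereas in compound 3 it is next to the ring atom that bears a large group. The expectation for compound 4 therefore rests on a single measured step, a number 18 percentage points higher from compound 1 to compound 2 (beyond the scatter), made on the other core. The step from compound 3 to compound 4 is estimated at a number 15 percentage points higher from compound 3 to compound 4 (beyond the scatter). That figure is set a little below a number 18 percentage points higher from compound 1 to compound 2 (beyond the scatter) to allow for the different surroundings of the changed carbon. Compound 4 is accordingly expected to give 35% in this assay, within a range of 20% to 50%.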

Compound 4, percent of the compound remaining: < 5%
Compound 4 ended at the assay's limit; the forecaster's own chance of this, stated with the estimate: 0%; middle value at least 30 percentage points from the limit.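

In this assay, pyridin-2-yl in place of pyridin-3-yl on an aromatic carbon gives a number at least 15 percentage points lower from compound 3 to compound 4 (beyond the scatter), which runs opposite to a number 18 percentage points higher from compound 1 to compound 2 (beyond the scatter). The change therefore does not carry from the core of compound 1 to the core of compound 3 as a fixed increment or even with its direction kept, although one pair on each core does not show why the two steps part or how the change would behave on any other core: the same change on two cores in this assay, a number 18 percentage points higher (beyond the scatter) from compound 1 to compound 2 and a number at least 15 percentage points lower (beyond the scatter) from compound 3 to compound 4, at least 33 percentage points apart, beyond the scatter of two such steps For compound 4, the reading < 5% is a limit of the assay and not a number, so the step from compound 3 has a known minimum but no known full size: the limit of < 5% in this assay, at which 1 of the 4 values shown sits.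

The compounds shown leave open which part of these molecules is lost in the assay, and whether the opposite steps persist when the pyridine is replaced by phenyl. They also leave open whether a carboxylic acid or an amine on the chain would change the readings on either core or alter the gap between the two steps.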